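Cyclopropylamino in place of hydroxymethyl on compound 3

The source may report more compounds than this note shows. Statements on the series, on what has been measured and on what is new or still open speak of the compounds shown alone.

Measured in a functional assay on SW-620 cells (Homo sapiens) for inhibition, read by MTT assay, with a stated time of 72 h; on this read-out lower numbers stand for stronger inhibition and higher numbers for weaker inhibition:
- compound 1 `COc1ccc(CNCc2c(OC)cc(Oc3cccc(Nc4ccccc4)c3)cc2OC)cc1`: 6970 nM
- compound 2 `COc1cc(Oc2cccc(Nc3ccccc3)c2)cc(OC)c1CNCc1ccc(C)cc1`: 11800 nM
- compound 3 `COc1cc(Oc2cccc(Nc3ccccc3)c2)cc(OC)c1CCO`: > 20000 nM (a limit, not a number)

Compound 3 stands at the limit of > 20000 nM in this assay, at which 1 of the 3 values shown sits, so its true position is open.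

The move to compound 4 `COc1cc(Oc2cccc(Nc3ccccc3)c2)cc(OC)c1CNC1CC1` changes one place: cyclopropylamino in place of hydroxymethyl on a saturated chain carbon bound to an aromatic carbon. Cyclopropylamino takes the place of hydroxymethyl on a saturated chain carbon bound to an aromatic carbon.

Among the measured compounds shown here, two measured steps bear on this change, both read in reverse, since each goes from an amine at this place to hydroxymethyl. The first is an at least 2.8-fold higher number from compound 1 to compound 3 (0.45 log units; beyond the scatter). The second is an at least 1.6-fold higher number from compound 2 to compound 3 (0.22 log units; that floor lies within the scatter). Both are floors, not exact sizes. The two amines themselves differ only by a 1.7-fold higher number from compound 1 to compound 2 (0.23 log units; within the scatter). For the measured compounds named here, no measured compound carries cyclopropylamino, so carrying these steps over to compound 4 is uncertain.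

A modest move towards a lower number is therefore expected, of about the size of those two steps. The expected step is an at least 1.6-fold lower number from compound 3 to compound 4 (0.22 log units; that floor lies within the scatter). A reading that is again only a limit remains possible. For compound 4 the estimate is 12000 nM, with an expected range from 6000 nM to 22000 nM.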

Compound 4, half-maximal inhibitory concentration: > 20000 nM
Compound 4 was reported as a limit (the forecaster's own chance of this, stated with the estimate: 25%); at least 1.6-fold (0.22 log units) between middle value and limit.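

In this assay compound 4 gives only a limit, so the step from compound 3 to compound 4 cannot be read, and the two compounds share the same limit: the limit of > 20000 nM in this assay, at which 2 of the 4 values shown sit.

The new information lies on the amine nitrogen. With the amine kept, cyclopropyl in place of 4-methoxybenzyl gives an at least 2.8-fold higher number from compound 1 to compound 4 (0.45 log units; beyond the scatter), while cyclopropyl in place of 4-methylbenzyl gives an at least 1.6-fold higher number from compound 2 to compound 4 (0.22 log units; that floor lies within the scatter), so only the first comparison clears the scatter. Among the compounds shown here, an amine at this place therefore does not by itself bring a reading under the limit, which the earlier compounds could not show, since both of their amines carried a substituted benzyl group.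

On these data alone, the true positions of compound 3 and compound 4 relative to each other stay open, as does the size of the loss on going from either benzyl amine to compound 4. Also open, as far as these compounds go, is whether an unsubstituted benzyl, a cyclohexyl or a longer alkyl chain on the amine nitrogen would give a number rather than a limit.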